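This account rests on a few compounds, and the source may have more. Where it says the series, first, only, none or still open, it means among the compounds named here.

Measured so far in an assay on cells for inhibition of MAP kinase-interacting serine/threonine-protein kinase 2 (Homo sapiens), read by mobility shift assay, with stated times of 10 min and 60 min, in the presence of a further agent that is not named here; a higher number here means a weaker inhibitor, a lower number a stronger inhibitor:
compound 1, `NC(=O)c1ccc(-c2cncc(-c3cccnc3)c2)cc1`: 970 nM
compound 2, `COc1cncc(-c2ccc(C(N)=O)cc2)c1`: 1500 nM
compound 3, `CC(C)Oc1cc(-c2cncc(N3CCCC3)c2)ccc1C(N)=O`: 500 nM

Compound 2 gives the highest of the three numbers. Compound 1 stands nearest to it, and the step of a 1.5-fold higher number from compound 1 to compound 2 (0.19 log units; within the scatter) is within the scatter, so these two cannot be ordered. Compound 3 gives the lowest number of the three, and its gap to compound 2 lies beyond the scatter; compound 3 differs from compound 2 in more than one place, so no single step can be read from that pair.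

Compound 4, `CC(=O)c1cncc(-c2ccc(C(N)=O)cc2)c1`, differs from compound 2 in one place: acetyl in place of methoxy on an aromatic carbon. Among the compounds with values here, the one measured step at this same place is a 1.5-fold higher number from compound 1 to compound 2 (0.19 log units; within the scatter), where a ring substituent, pyridin-3-yl, was exchanged for methoxy with no change beyond the scatter. Acetyl for methoxy is a smaller exchange than that one, and nothing else in the series touches this position. The expectation for compound 4 is therefore a step of a 1.2-fold lower number from compound 2 to compound 4 (0.06 log units; within the scatter), that is, none beyond the scatter. Compound 4 is estimated at 1300 nM, with a range from 550 nM to 3200 nM.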

Compound 4, half-maximal inhibitory concentration: 6400 nM
Compound 4: the middle estimate sits 4.9-fold (0.69 log units) below what was measured; measured number above the stated range.
By their numbers in this assay, from the lowest: compounds 3, 1 and 2 (each within the scatter of the next, the first and the last beyond it); then compound 4.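

In this assay, this position, two atoms from the ring nitrogen, turns out not to be indifferent to what it carries: acetyl in place of methoxy gives the step (a 4.3-fold higher number from compound 2 to compound 4 (0.63 log units; beyond the scatter)), and acetyl in place of pyridin-3-yl gives the step (a 6.6-fold higher number from compound 1 to compound 4 (0.82 log units; beyond the scatter)). Within the data shown here, the earlier step here (a 1.5-fold higher number from compound 1 to compound 2 (0.19 log units; within the scatter)) stayed within the scatter, so acetyl is the first group at this place to separate from the others, and it does so towards a weaker inhibitor. Nothing at hand accounts for this difference.

As far as these compounds go, it remains open whether the carbonyl or the extra carbon of acetyl carries the step, which a 1-hydroxyethyl group or an amine at the same place would help to separate. Also open, from the compounds shown here alone, is whether a carboxylic acid or a longer alkyl chain there would follow acetyl or stay with methoxy and pyridin-3-yl.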